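A few compounds are considered here, and "the series" means these few. Any claim that something is new, unique, unknown or untested is made for them only; others in the source may bear on it.

Compound 1 `Cn1c(=O)c(=O)n(C2CCCC2)c2nc(N/N=C/c3ccc(C(F)(F)F)cc3)ncc21`: 23600 nM
Compound 2 `Cn1c(=O)c(=O)n(C2CCCC2)c2nc(N/N=C/c3ccco3)ncc21`: 72200 nM
Compound 3 `Cn1c(=O)c(=O)n(C2CCCC2)c2nc(N/N=C/c3ccc(F)cc3Cl)ncc21`: 15200 nM

All three have been compared in a functional assay on PC-3 cells (Homo sapiens) for antiproliferative activity, read by MTT assay; a lower number here means a stronger inhibitor, a higher number a weaker inhibitor. Compound 3 shows the lowest of the three numbers. Its nearest neighbour is compound 1, with a 1.6-fold lower number from compound 1 to compound 3 (0.19 log units; within the scatter), a step within the scatter; its furthest is compound 2, with a 4.8-fold lower number from compound 2 to compound 3 (0.68 log units; beyond the scatter), a step beyond the scatter. The remaining step, a 3.1-fold higher number from compound 1 to compound 2 (0.49 log units; beyond the scatter), also sets the furan-2-yl compound apart from a substituted phenyl compound.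

Compound 4 `Cn1c(=O)c(=O)n(C2CCCC2)c2nc(N/N=C/c3ccc(F)cc3Br)ncc21` differs from compound 3 by bromo in place of chloro on an aromatic carbon. Going by the values given here, none of the measured steps exchanges one halogen for another on an otherwise unchanged ring; each replaces the whole group on the carbon with a double bond to nitrogen. The closest comparison is a 1.6-fold lower number from compound 1 to compound 3 (0.19 log units; within the scatter), where two differently substituted phenyl groups give numbers within the scatter. On that basis no step beyond the scatter is expected in this assay, a 1.0-fold lower number from compound 3 to compound 4 (0.01 log units; within the scatter). Compound 4 is accordingly estimated at 15000 nM, with a range from 7000 nM to 32000 nM.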

Compound 4, half-maximal inhibitory concentration: 9250 nM
The estimate for compound 4 lay 1.6-fold (0.21 log units) above the measured number, and the stated range covers the measured number.
By their numbers in this assay, from the lowest: compounds 4, 3 and 1 (each within the scatter of the next, the first and the last beyond it); then compound 2.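

Going by these compounds alone, this is the first exchange confined to a single atom on the ring: in this assay, bromo in place of chloro on an aromatic carbon gives a 1.6-fold lower number from compound 3 to compound 4 (0.22 log units; within the scatter), so either halogen is accepted here without a step that can be told from the scatter. Against the other groups on the carbon with a double bond to nitrogen, the 2-bromo-4-fluorophenyl compound gives a 7.8-fold lower number from compound 2 to compound 4 (0.89 log units; beyond the scatter) and a 2.6-fold lower number from compound 1 to compound 4 (0.41 log units; beyond the scatter), both beyond the scatter, whereas a 1.6-fold lower number from compound 1 to compound 3 (0.19 log units; within the scatter) stayed within it. Nothing available on hand offers an explanation for these numbers.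

Going by these compounds, whether a hydrogen, a methoxy group or an amine in place of the halogen would stay within the scatter of compound 3 remains open. Also open, on these data alone, is whether the halogen exchange reads the same once the fluoro group is removed.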